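The compounds below may be only part of what the source reports. "The series", "measured", "known", "first", "only" and "open" are said of these compounds alone.

Of the compounds shown here, three have been measured in an assay on isolated protein for inhibition of lysosomal alpha-glucosidase (Rattus norvegicus), tested at 100 uM; a lower number here means less inhibition, a higher number more inhibition at the concentration tested (going by the name of the read-out). Compound 1 `O=C(/C=C/c1ccc(Cl)cc1)C[C@@H]1O[C@H](CO)[C@@H](O)[C@H](O)[C@H]1O` gives -5.97% and stands second highest of the three numbers; its nearest neighbour is compound 3 `CCOC(=O)C(C(=O)OCC)C(CC(=O)C[C@@H]1O[C@H](CO)[C@@H](O)[C@H](O)[C@H]1O)c1ccc(OC)c(OC)c1`, which gives -2.3%, a number within the scatter of it, while compound 2 `CCOC(=O)C(C(=O)OCC)C(CC(=O)C[C@@H]1O[C@H](CO)[C@@H](O)[C@H](O)[C@H]1O)c1ccc2ccccc2c1` gives -20%, a number beyond the scatter. Compound 4 `O=C(/C=C/c1ccccc1)C[C@@H]1O[C@H](CO)[C@@H](O)[C@H](O)[C@H]1O` is not yet measured. It differs from compound 1 by hydrogen in place of chloro on an aromatic carbon. Within the data shown here, no measured step removes a chloro in this way: the only measured step, a number 17.7 percentage points higher from compound 2 to compound 3 (beyond the scatter), concerns a swap of aromatic groups elsewhere on the chain, so it offers little guidance here. Since all three numbers sit near zero, compound 4 is expected to show no step beyond the scatter, a number 1 percentage points higher from compound 1 to compound 4 (within the scatter), with an estimated -5% ranging from -20% to 10%.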

Compound 4, a percentage reported as inhibition, at one concentration (the size of the read-out at that concentration, not a potency): -10.4%
For compound 4 the middle estimate is 5.4 percentage points above the measured one; the measured number falls inside the stated range.
By their numbers in this assay, from the lowest: compounds 2, 4, 1 and 3 (each within the scatter of the next, the first and the last beyond it).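

Going from 4-chlorophenyl to phenyl in this assay gives a number 4.4 percentage points lower from compound 1 to compound 4 (within the scatter), so at this place on the aromatic ring, chloro and hydrogen cannot be told apart. Both compounds give negative numbers, so neither group brings out any inhibition at the concentration tested. Nothing available explains this result. From the compounds shown here alone, whether a different group at this place, such as an amine or a carboxylic acid, would bring a positive number remains open. So does whether any such change would matter with the carbon-carbon double bond of the chain removed.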